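Amino acid amides on a chloro quinolinone core: glycine analogue

A few compounds are considered here, and "the series" means these few. Any claim that something is new, unique, unknown or untested is made for them only; others in the source may bear on it.

Compound 3 `CC(C)C[C@@H](N)C(=O)Nc1cc2cc[nH]c(=O)c2cc1Cl` gives 700 nM in a functional assay (aorta) with Rattus norvegicus as the target (a higher number here means that more compound is needed for the effect, a lower number that less compound is needed), the higher of the two numbers recorded for this set; compound 1 `CC(C)[C@H](N)C(=O)Nc1cc2cc[nH]c(=O)c2cc1Cl` gives 500 nM, and the gap a 1.4-fold higher number from compound 1 to compound 3 (0.15 log units; within the scatter) lies within the scatter. Compound 2 `O=C(Nc1cc2cc[nH]c(=O)c2cc1Cl)[C@@H]1CCCN1` has "not determined" (no result reported) in this assay, so it adds nothing to the comparison.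

Compound 4 `NCC(=O)Nc1cc2cc[nH]c(=O)c2cc1Cl` is the next step from compound 3: hydrogen in place of isobutyl on a saturated chain carbon bound to an amine nitrogen and a carbonyl carbon. For the measured compounds named here, the only measured step that bears on it is the one from compound 1 to compound 3, a swap of one branched side chain for another, and it stayed within the scatter. That gives no sign that the side chain on this carbon sets the number, but removing it entirely goes further than any step measured here, so the expectation rests on a single comparison.

Compound 4 is therefore expected to stay close to compound 3, with a change of a 1.3-fold higher number from compound 3 to compound 4 (0.11 log units; within the scatter) in this assay, if anything a slight drift to a higher number. The estimate for compound 4 is 900 nM, with a range of 300 nM to 2700 nM.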

Compound 4, half-maximal effective concentration: 2500 nM
Compound 4: middle estimate off by 2.8-fold (0.44 log units), on the low side, and the stated range covers the measured number.
By their numbers in this assay, from the lowest: compounds 1 and 3 (each within the scatter of the next); then compound 4.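

On the saturated chain carbon bound to an amine nitrogen and a carbonyl carbon, the side chain does affect the number in this assay: hydrogen in place of isobutyl gives a 3.6-fold higher number from compound 3 to compound 4 (0.55 log units; beyond the scatter) and hydrogen in place of isopropyl gives a 5.0-fold higher number from compound 1 to compound 4 (0.70 log units; beyond the scatter) in this series. Compound 1 and compound 3 read alike while compound 4 stands apart, so among these compounds, having a side chain on this carbon counts for more than which of the two branched chains it is. No measured evidence here bears on why the number rises with hydrogen at this place.

On these data alone, whether a methyl group on this carbon already gives a number like those of compound 1 and compound 3, or a longer chain or a carboxylic acid there shifts it further, stays open. Steps involving compound 2 cannot be read, so a ring closed from this carbon onto the amine nitrogen remains uninformative.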